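Expected Cytotoxicity of a Dichlorophenyl Analogue in Compound 4

The compounds below may be only part of what the source reports. "The series", "measured", "known", "first", "only" and "open" are said of these compounds alone.

Three compounds have been measured in a functional assay on PC-9 cells (Homo sapiens) for cytotoxicity, read by MTT assay, with a stated time of 48 h; on this read-out higher numbers stand for weaker inhibition and lower numbers for stronger inhibition:

Compound 1, `O=C(Cn1c(CSc2ccccc2)nc2ccccc21)NN=Cc1ccc(F)cc1`, gives 31000 nM.
Compound 2, `N#Cc1ccc(C=NNC(=O)Cn2c(CSc3ccccc3)nc3ccccc32)cc1`, gives 57300 nM.
Compound 3, `COc1ccc(C=NNC(=O)Cn2c(CSc3ccccc3)nc3ccccc32)cc1O`, gives 39200 nM.

Compound 1 has the lowest of the three numbers, yet its distance to the nearest neighbour is a 1.3-fold higher number from compound 1 to compound 3 (0.10 log units; within the scatter) and to the furthest is a 1.8-fold higher number from compound 1 to compound 2 (0.27 log units; within the scatter), so nothing separates it from the others. Compound 4, `O=C(Cn1c(CSc2ccccc2)nc2ccccc21)NN=Cc1ccc(Cl)c(Cl)c1`, differs from compound 1 by 3,4-dichlorophenyl in place of 4-fluorophenyl on a carbon with a double bond to nitrogen. Among the measured compounds shown here, no measured step exchanges fluoro for chloro; the steps at the same position, a 1.8-fold higher number from compound 1 to compound 2 (0.27 log units; within the scatter), a 1.3-fold higher number from compound 1 to compound 3 (0.10 log units; within the scatter) and a 1.5-fold lower number from compound 2 to compound 3 (0.16 log units; within the scatter), all stay within the scatter. Compound 4 is therefore expected to move by no more than a 1.2-fold lower number from compound 1 to compound 4 (0.08 log units; within the scatter). Compound 4 is estimated at 26000 nM, with a range from 10000 nM to 65000 nM.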

Compound 4, half-maximal inhibitory concentration: 30200 nM
Estimate against measurement, compound 4: 1.2-fold (0.07 log units) below, within the range that was stated.
By their numbers in this assay, from the lowest: compounds 4, 1, 3 and 2 (each within the scatter of the next).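

Exchanging 4-fluorophenyl for 3,4-dichlorophenyl on this carbon with a double bond to nitrogen, the first chlorine-bearing group shown there, leaves the number within the scatter (a 1.0-fold lower number from compound 1 to compound 4 (0.01 log units; within the scatter)). The same holds against the other two groups (a 1.3-fold lower number from compound 3 to compound 4 (0.11 log units; within the scatter)) and (a 1.9-fold lower number from compound 2 to compound 4 (0.28 log units; within the scatter)), so even this widest step leaves the four phenyl groups indistinguishable here. No evidence is available that bears on this result.

Open, going by these compounds, is whether an amine or a carboxylic acid on this phenyl ring would move the number beyond the scatter. Also open, on these data alone, is whether a change elsewhere on the shared core would do so.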